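The source may hold more compounds than are shown below. What is called first, only, known or untested is meant among the compounds shown, and "the series" means these compounds.

Compound 1 `Nc1ncnc2c1ncn2[C@@H]1O[C@H](CN(CC[C@H](N)C(=O)O)CC2CC2)[C@@H](O)[C@H]1O` gives 27.5% in an assay for inhibition of tRNA (cytosine(38)-C(5))-methyltransferase (Homo sapiens), with a stated time of 5 min, tested at 100 uM (a higher number here means more inhibition at the concentration tested (going by the name of the read-out), a lower number less inhibition), while compound 2 `C#CCN(CC[C@H](N)C(=O)O)C[C@H]1O[C@@H](n2cnc3c(N)ncnc32)[C@H](O)[C@@H]1O` gives 72.2% and stands highest of the two numbers. Within the data shown here, the one step seen so far, a number 44.7 percentage points higher from compound 1 to compound 2 (beyond the scatter), shows that this position of the molecule matters strongly. Compound 3 `CC#CCN(CC[C@H](N)C(=O)O)C[C@H]1O[C@@H](n2cnc3c(N)ncnc32)[C@H](O)[C@@H]1O` carries methyl in place of hydrogen on a triple-bonded carbon. No measured step adds a methyl at a triple-bonded carbon, so the expectation rests only on the sensitivity shown at this place; a moderate loss is expected, a step of a number 17.2 percentage points lower from compound 2 to compound 3 (beyond the scatter). Compound 3 is therefore estimated at 55%, with a range from 25% to 80%.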

Compound 3, a percentage reported as inhibition, at one concentration (the size of the read-out at that concentration, not a potency): 61.3%
The estimate for compound 3 lay 6.3 percentage points below the measured number; measured number inside the range.
By their numbers in this assay, from the lowest: compound 1; then compound 3; then compound 2.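

In this assay, methyl in place of hydrogen on a triple-bonded carbon gives a number 10.9 percentage points lower from compound 2 to compound 3 (beyond the scatter) and so shows that the ethynyl hydrogen can be replaced at a modest cost. The triple bond with this added methyl also keeps most of the gain over cyclopropyl, with a number 33.8 percentage points higher from compound 1 to compound 3 (beyond the scatter) as the step between those two groups. Nothing available gives a reason for either step. What the compounds shown leave open is how a longer chain, an amine or a carboxylic acid would fare in place of this methyl.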